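From cyanomethyl to ethyl in a cytotoxicity series

The source may report more compounds than this note shows. Statements on the series, on what has been measured and on what is new or still open speak of the compounds shown alone.

Results so far in a functional assay on MCF7 cells (Homo sapiens) for cytotoxicity, read by sulforhodamine B assay, with a stated time of 48 h; on this read-out lower numbers stand for stronger inhibition and higher numbers for weaker inhibition 

- compound 1 (`N#Cc1c(-c2ccc(Cl)cc2)cc(-c2ccc(Cl)cc2)n(C(=O)c2ccccc2)c1=O`) gives 2.6 ug/mL 
- compound 2 (`N#CCn1c(-c2ccc(Cl)cc2)cc(-c2ccc(Cl)cc2)c(C#N)c1=O`) gives "not active" (no number reported) 

In this assay compound 2 has no single number to stand on. It is reported without a value, while compound 1 gives a measurable half-maximal inhibitory concentration (2.6 ug/mL).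

Compound 3 (`CCn1c(-c2ccc(Cl)cc2)cc(-c2ccc(Cl)cc2)c(C#N)c1=O`) has not yet been measured. It departs from compound 2 in one place (methyl in place of cyano on a saturated chain carbon bound to an aromatic nitrogen), with methyl in place of cyano on a saturated chain carbon bound to an aromatic nitrogen, so that cyanomethyl becomes ethyl. Among the compounds with values here, no measured step guides this change, and compound 2 offers no number to start from. A move towards stronger inhibition in this assay is expected, of uncertain size, although compound 3 may also be reported without a number. If a number is reported, compound 3 is expected at 12 ug/mL with an estimated range (3 ug/mL to 50 ug/mL).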

Compound 3, half-maximal inhibitory concentration: 19.7 ug/mL
For compound 3 the middle estimate is 1.6-fold (0.22 log units) below the measured one; low and high end bracket the measured number.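

In this assay compound 3, with ethyl on the aromatic nitrogen, gives 19.7 ug/mL as a measurable value, whereas cyanomethyl at the same place in compound 2 gave no number, so the size of that change cannot be read. Putting ethyl in place of benzoyl on the aromatic nitrogen gives a 7.6-fold higher number from compound 1 to compound 3 (0.88 log units; beyond the scatter) and this step lies beyond the usual scatter, which shows that the group at this place changes the read-out and that ethyl does not match benzoyl here. No evidence on hand bears on why these groups differ.

Going by these compounds, whether a longer chain such as propyl would keep or improve on the value of ethyl remains open. So does whether an acetyl or a benzyl group would show if the lead of benzoyl goes with its carbonyl or with its ring.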